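A few compounds are considered here, and "the series" means these few. Any claim that something is new, unique, unknown or untested is made for them only; others in the source may bear on it.

Three measured compounds share one core and differ only in the group on a sulfonyl sulfur. In a physicochemical assay for solubility, in phosphate buffer, with a stated time of 24 h, at pH 7.4, tested at 100 uM (on this read-out higher numbers stand for higher solubility and lower numbers for lower solubility), compound 1 (`O=C(NCc1ccc(S(=O)(=O)c2cccc(C(F)(F)F)c2)cc1)N1Cc2ccncc2C1`) gives 10000 nM and carries a 3-(trifluoromethyl)phenyl group there. Compound 2 (`CC(C)n1cc(S(=O)(=O)c2ccc(CNC(=O)N3Cc4ccncc4C3)cc2)cn1`) gives 192000 nM with a 1-isopropyl-1H-pyrazol-4-yl group, and compound 3 (`O=C(NCc1ccc(S(=O)(=O)N2CCC[C@H](O)C2)cc1)N1Cc2ccncc2C1`) gives 215000 nM with a 3-hydroxypiperidin-1-yl group. Compound 3 shares the upper end of these numbers with compound 2 and lies far from compound 1. The gaps are a 1.1-fold higher number from compound 2 to compound 3 (0.05 log units; within the scatter) on one side and a 22-fold higher number from compound 1 to compound 3 (1.33 log units; beyond the scatter) on the other.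

The next compound, compound 4 (`O=C(NCc1ccc(S(=O)(=O)N2CCC(N3CCCC3)CC2)cc1)N1Cc2ccncc2C1`), keeps the core, and 4-(pyrrolidin-1-yl)piperidin-1-yl comes in place of 3-hydroxypiperidin-1-yl on the sulfonyl sulfur. Counted, the change reads 4-(pyrrolidin-1-yl)piperidin-1-yl in place of 3-hydroxypiperidin-1-yl on a sulfonyl sulfur in full. Two large steps are on record, a 19-fold higher number from compound 1 to compound 2 (1.28 log units; beyond the scatter) and a 22-fold higher number from compound 1 to compound 3 (1.33 log units; beyond the scatter) as already seen, but both start from the 3-(trifluoromethyl)phenyl group, which plays no part here. Among the compounds with values here, the one measured step that avoids that group, a 1.1-fold higher number from compound 2 to compound 3 (0.05 log units; within the scatter) as its size, stayed small, and it is the closest guide. The expected step is a 1.1-fold lower number from compound 3 to compound 4 (0.03 log units; within the scatter) and so no change beyond the scatter is expected in either direction. In this assay compound 4 is estimated at 200000 nM and expected to fall between 90000 nM and 350000 nM.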

Compound 4, solubility: 6200 nM
The estimate for compound 4 lay 32-fold (1.51 log units) above the measured number; the measured number lies below the stated range.
By their numbers in this assay, from the lowest: compounds 4 and 1 (each within the scatter of the next); then compounds 2 and 3 (each within the scatter of the next).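

At this sulfonyl sulfur, one non-aromatic ring group cannot stand in for another: in this assay, putting 4-(pyrrolidin-1-yl)piperidin-1-yl in place of 3-hydroxypiperidin-1-yl gives a 35-fold lower number from compound 3 to compound 4 (1.54 log units; beyond the scatter), and the change from the 1-isopropyl-1H-pyrazol-4-yl group gives a step of like size, a 31-fold lower number from compound 2 to compound 4 (1.49 log units; beyond the scatter). Until now every large step began at the 3-(trifluoromethyl)phenyl group, yet this low number arises with a group that has no aromatic ring, and the gap to that group's compound is no more than a 1.6-fold lower number from compound 1 to compound 4 (0.21 log units; within the scatter). Nothing measured in these data says what lies behind the large step.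

The single change removes the hydroxy group, adds the pyrrolidine ring and enlarges the substituent all at once, so the compounds shown cannot assign the step to any one of these. A 4-hydroxypiperidin-1-yl group or a 4-(dimethylamino)piperidin-1-yl group on the same sulfur would help to pull those parts apart, since each keeps only some of the features of the two groups compared here.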